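Extending the chain on compound 2 toward compound 4

This account rests on a few compounds, and the source may have more. Where it says the series, first, only, none or still open, it means among the compounds named here.

Of the compounds shown here, three of a shared core have been measured in an assay on cells for binding affinity to vitamin D3 receptor (Homo sapiens), read by fluorescence, tested at 1 uM; on this read-out higher numbers stand for more inhibition at the one concentration tested (going by the name of the read-out) and lower numbers for less inhibition. Compound 1 `CCC(CC)(c1ccc(OS(=O)(=O)c2ccc(C)cc2)c(C)c1)c1ccc(OCC(=O)C(C)(C)C)c(OCC(=O)C(C)(C)C)c1` gives 35%, compound 2 `CCC(CC)(c1ccc(OCCO)c(C)c1)c1ccc(OCC(O)C(C)(C)C)c(OCC(O)C(C)(C)C)c1` gives 38%, and compound 3 `CCC(CC)(c1ccc(OCCCO)c(C)c1)c1ccc(OCC(O)C(C)(C)C)c(OCC(O)C(C)(C)C)c1` gives 76%. Compound 2 stands second highest of the three; its gap to compound 1 lies within the scatter, while compound 3 sits beyond it, with a number 38 percentage points higher from compound 2 to compound 3 (beyond the scatter).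

Compound 4 `CCC(CC)(c1ccc(OCCCCCO)c(C)c1)c1ccc(OCC(O)C(C)(C)C)c(OCC(O)C(C)(C)C)c1` differs from compound 2 as follows: 3-hydroxypropyl in place of hydroxy on a saturated chain carbon, two bonds along the chain from an oxygen on an aromatic ring. Going by the values given here, the only step that bears on this is the one from compound 2 to compound 3, where a hydroxymethyl replaced the hydroxy at the same place and the number rose sharply. Compound 4 is therefore expected to give 65%, between 40% and 90%, an expected step of a number 27 percentage points higher from compound 2 to compound 4 (beyond the scatter).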

Compound 4, a percentage reported as inhibition, at one concentration (the size of the read-out at that concentration, not a potency): 67%
The estimate for compound 4 lay 2 percentage points below the measured number, and the stated range covers the measured number.
By their numbers in this assay, from the lowest: compounds 1 and 2 (each within the scatter of the next); then compounds 4 and 3 (each within the scatter of the next).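

In this assay the gain at this position is not confined to hydroxymethyl: 3-hydroxypropyl in place of the hydroxy also gives a number 29 percentage points higher from compound 2 to compound 4 (beyond the scatter). Replacing the hydroxy three bonds along the chain with 2-hydroxyethyl gives a number 9 percentage points lower from compound 3 to compound 4 (within the scatter), so these two chains cannot be told apart on this read-out. On these data alone, whether a longer chain would hold this level, and whether an amine or a carboxylic acid could take the place of the hydroxy at the chain end, stays open. Nothing available explains the difference between the shorter and the longer chains.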